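This account rests on a few compounds, and the source may have more. Where it says the series, first, only, none or still open, it means among the compounds named here.

In a functional assay on the whole organism (strain albino) for inhibition, with Rattus norvegicus as the target, read by paw edema, with stated times of 30 min and 4 h, at a dose of 100 mg/kg by the oral route (on this read-out higher numbers stand for more inhibition at the one dose given (going by the name of the read-out) and lower numbers for less inhibition), compound 3 `C/C(=N/O)c1ccc(OCC(=O)Nc2ccc(C(=O)/C=C/c3ccc(Cl)cc3)cc2)cc1` gives 55%, the highest of the three numbers recorded. Compound 1 `COc1ccc(/C=C/C(=O)c2ccc(NC(=O)CBr)cc2)cc1` gives 41%, a number beyond the scatter below that of compound 3, and compound 2 `COc1ccc(/C=C/C(=O)c2ccc(NC(=O)COc3ccc(C(C)=O)cc3)cc2)cc1` gives 33%, further below it still. Within the data shown here, the only step between two measured compounds that differ in one place is a number 8 percentage points lower from compound 1 to compound 2 (within the scatter), a change of a different group that does not touch the place where compound 3 carries its chloro.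

Compound 4 `COc1ccc(/C=C/C(=O)c2ccc(NC(=O)COc3ccc(/C(C)=N\O)cc3)cc2)cc1` differs from compound 3 in a single place: methoxy in place of chloro on an aromatic carbon. No measured step bears directly on this exchange; none of the recorded pairs swaps chloro for methoxy. Compounds 1 and 2 carry the methoxy that enters here, and both sit below compound 3, but each also differs from compound 3 elsewhere, so their values do not isolate the exchange. Among the measured compounds shown here, with no direct precedent, only a modest shift is expected, if any beyond the scatter, and the step is estimated as a number 10 percentage points lower from compound 3 to compound 4 (within the scatter). Compound 4 is therefore expected to give about 45%, within a range from 30% to 60%.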

Compound 4, a percentage reported as inhibition, in the whole organism at one dose (the size of the read-out at that dose, not a potency): 42%
Compound 4: the middle estimate sits 3 percentage points above what was measured; the measured number falls inside the stated range.
By their numbers in this assay, from the lowest: compounds 2, 1 and 4 (each within the scatter of the next); then compound 3.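

In this assay, among these compounds, methoxy in place of chloro on the aromatic carbon gives the first direct reading at this position, a number 13 percentage points lower from compound 3 to compound 4 (beyond the scatter), so the exchange of 4-chlorophenyl for 4-methoxyphenyl is one that this read-out can register. With methoxy held in place, the two changes elsewhere give smaller readings: the group of 4 heavy atoms in place of the group of 3 heavy atoms on an aromatic carbon gives a number 9 percentage points higher from compound 2 to compound 4 (within the scatter), and the group of 11 heavy atoms in place of bromine gives a number 1 percentage points higher from compound 1 to compound 4 (within the scatter), so of the three new steps only the exchange of chloro for methoxy stands clear of the scatter. The data offer nothing that accounts for the size or direction of this step.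

On these data alone, this position is known from chloro and methoxy alone, so how a fluoro, a methyl, a dimethylamino or a bare hydrogen at the same aromatic carbon would read remains open. Among the compounds shown here, it also remains open whether the same exchange would give a similar step in the bromo compound or the 4-acetylphenoxy compound, since the only direct pair is the one carrying the group of 4 heavy atoms.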